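Methylsulfanyl for dimethylamino on a purine nucleoside core

The compounds below may be only part of what the source reports. "The series", "measured", "known", "first", "only" and "open" are said of these compounds alone.

Compound 1 `CN(C)c1nc(N)c2ncn([C@@H]3C[C@@H](O)[C@H](CO)O3)c2n1` sits at the limit of a functional assay on PHA-Ly cells (Homo sapiens); a higher number here means a weaker inhibitor, a lower number a stronger inhibitor: in this assay compound 1 gives > 300 uM, a limit and not a number (the limit of > 300 uM in this assay, at which 1 of the 2 values shown sits). Compound 2 `CN(C)c1nc(Br)nc2c1ncn2[C@@H]1C[C@@H](O)[C@H](CO)O1`, the bromo analogue, gives 88 uM in this assay. Compound 3 `CSc1nc(N)c2ncn([C@@H]3C[C@@H](O)[C@H](CO)O3)c2n1` carries methylsulfanyl in place of dimethylamino on an aromatic carbon. For the measured compounds named here, with compound 1 known only as a limit, no measured step guides the change; the step from compound 1 to compound 3 is expected to be a number no higher from compound 1 to compound 3 (the limit leaves the size open), no more than the scatter. Compound 3 is therefore estimated at 300 uM in this assay, within 80 uM to 1000 uM, with a fair chance that only a limit is reported again.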

Compound 3, concentration for 50% inhibition: 82 uM
Beside the measured number, compound 3's estimate is 3.7-fold (0.56 log units) above it; measured number inside the range.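

Methylsulfanyl in place of dimethylamino, on the aromatic carbon between two ring nitrogen atoms, gives an at least 3.6-fold lower number from compound 1 to compound 3 (0.56 log units; beyond the scatter) in this assay. This position therefore responds to a change of group, and compound 3 brings the series off the limit with a measured number. The step remains a bound and not a size: the limit of > 300 uM in this assay, at which 1 of the 3 values shown sits.

Going by these compounds, how a methoxy group, an amine or a longer alkylsulfanyl chain would read at this position remains open. So does whether methylsulfanyl keeps this effect when the amino group on the shared core is replaced by another group.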